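Moving the Pyridine Nitrogen on a Spiro Piperidine Core

The compounds below may be only part of what the source reports. "The series", "measured", "known", "first", "only" and "open" are said of these compounds alone.

Compound 1, `COc1ccc2[nH]c3c(c2c1)CCNC31CCN(Cc2ccc(F)cc2F)CC1`, gives 2000 nM in an assay on FRT cells for positive allosteric modulation of Cystic fibrosis transmembrane conductance regulator variant N1303K (Homo sapiens), in the presence of a further agent that is not named here; on this read-out higher numbers stand for an effect only at larger amounts of compound and lower numbers for an effect already at smaller amounts.
Compound 2, `COc1ccc2[nH]c3c(c2c1)CCNC31CCN(Cc2ccccn2)CC1`, gives 11500 nM in this assay.

Within the data shown here, compound 2 stands at the higher of these two numbers, and its only comparison is the single measured step, a 5.8-fold higher number from compound 1 to compound 2 (0.76 log units; beyond the scatter), which replaces one aromatic ring with another on the same chain carbon.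

Compound 3, `COc1ccc2[nH]c3c(c2c1)CCNC31CCN(Cc2cccnc2)CC1`, differs from compound 2 in one place: pyridin-3-yl in place of pyridin-2-yl on a saturated chain carbon bound to an amine nitrogen in a ring. Among the measured compounds shown here, no measured step covers this kind of change; the one step known concerns a different ring swap and says little about shifting a nitrogen within the same ring. With nothing pushing in either direction, compound 3 is expected to land close to compound 2, the estimated step being a 1.3-fold lower number from compound 2 to compound 3 (0.11 log units; within the scatter), inside the scatter. The estimate for compound 3 in this assay is 9000 nM, with a range from 3000 nM to 30000 nM.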

Compound 3, half-maximal effective concentration: 17000 nM
The estimate for compound 3 lay 1.9-fold (0.28 log units) below the measured number, within the range that was stated.
By their numbers in this assay, from the lowest: compound 1; then compounds 2 and 3 (each within the scatter of the next).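

Within the pyridine series, shifting the ring nitrogen on this chain carbon makes no readable difference: a 1.5-fold higher number from compound 2 to compound 3 (0.17 log units; within the scatter) is a step inside the scatter, so pyridin-2-yl and pyridin-3-yl cannot be told apart in this assay. The larger gap now appears with a second pyridine, since an 8.5-fold higher number from compound 1 to compound 3 (0.93 log units; beyond the scatter) lies beyond the scatter, just as the step to compound 2 does, and so among these three compounds the 2,4-difluorophenyl group stands apart from both pyridines. Nothing available here explains this gap.

As far as these compounds go, what remains open is how a plain phenyl or a pyridin-4-yl group would read at this position. Also open, from the compounds shown here alone, is whether a longer chain between the ring nitrogen and the aromatic ring, or an amine in place of that aromatic ring, would shift the number at all.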